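Working notes on the step from compound 3 to compound 4

A few compounds are considered here, and "the series" means these few. Any claim that something is new, unique, unknown or untested is made for them only; others in the source may bear on it.

Compound 3, `Cc1nnc(SCC(=O)c2ccccc2)n1N1C(=O)c2ccccc2C1=O`, is tested in a functional assay on MKN-45 cells (Homo sapiens) for cytotoxicity, read by MTT assay, with a stated time of 48 h; a lower number here means a stronger inhibitor, a higher number a weaker inhibitor. In this assay compound 3 gives > 200000 nM, which is a limit of the assay and not a number. Compound 1, `Cc1nnc(SCc2ccccc2)n1N1C(=O)c2ccccc2C1=O`, gives > 200000 nM in this assay, again a limit. Compound 2, `Cc1ccc(C(=O)CSc2nnc(C)n2N2C(=O)c3ccccc3C2=O)cc1`, gives > 200000 nM in this assay, also a limit. All three values sit at the limit of > 200000 nM in this assay, at which 3 of the 3 values shown sit. The three steps among them, a step that the two limits leave unreadable from compound 1 to compound 2, a step that the two limits leave unreadable from compound 1 to compound 3 and a step that the two limits leave unreadable from compound 2 to compound 3, therefore cannot be read for size or direction.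

Compound 4 is `Cc1nnc(SCc2ccccc2Cl)n1N1C(=O)c2ccccc2C1=O`. It differs from compound 3 by 2-chlorophenyl in place of benzoyl on a saturated chain carbon bound to a sulfur. The measured steps that bear on this change are a step that the two limits leave unreadable from compound 1 to compound 3 and a step that the two limits leave unreadable from compound 1 to compound 2, both of which exchange the group on the saturated chain carbon bound to a sulfur, and neither of which gives a readable size. Within the data shown here, no step leaves the limit, so no direction can be expected for the step to compound 4 beyond the scatter. The expected step from compound 3 to compound 4 is a number no higher from compound 3 to compound 4 (the limit leaves the size open). In this assay compound 4 is estimated at 200000 nM, with a range from 50000 nM to 400000 nM, and the most likely outcome is again a limit.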

Compound 4, half-maximal inhibitory concentration: > 200000 nM
Compound 4: a limit, no number; the forecaster's own chance of this, stated with the estimate: 80%; the middle value lies on the limit itself.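

The steps from compound 4 to compound 1, compound 2 and compound 3 cannot be read for size or direction, as all four compounds give only a limit: the limit of > 200000 nM in this assay, at which 4 of the 4 values shown sit. The compounds shown leave open what size or direction any exchange of the group on the saturated chain carbon bound to a sulfur has.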